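Swapping a pentyl chain for a hydroxy group

A few compounds are considered here, and "the series" means these few. Any claim that something is new, unique, unknown or untested is made for them only; others in the source may bear on it.

Compound 1 `CCCCCc1cc(C)c(C(=O)N=C(N)N)cc1S(C)(=O)=O` carries a pentyl chain on its aromatic core and in a functional assay for inhibition of sodium/hydrogen exchanger (Oryctolagus cuniculus) (on this read-out lower numbers stand for stronger inhibition and higher numbers for weaker inhibition), compound 1 gives 27 nM. Among the three measured compounds it stands second highest; its nearest neighbour is compound 3 `Cc1cc(SC(C)(C)C)c(S(C)(=O)=O)cc1C(=O)N=C(N)N`, which in this assay gives 22 nM, and furthest away is compound 2 `Cc1cc(Br)c(C(=O)N=C(N)N)cc1S(C)(=O)=O`, which gives 70 nM. Within the data shown here, the one single-point step that has been measured, a 1.2-fold lower number from compound 1 to compound 3 (0.09 log units; within the scatter), shows that a bulky lipophilic replacement for the pentyl chain leaves the inhibitory potency essentially unchanged.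

The new compound 4 `Cc1cc(O)c(S(C)(=O)=O)cc1C(=O)N=C(N)N` differs from compound 1 as follows: hydroxy in place of pentyl on an aromatic carbon. Among the measured compounds shown here, no measured step covers a replacement of this kind, so the change from a long chain to a single small polar group is untested here. The nearby evidence from compound 3 cannot be carried over directly, and the estimate that follows is therefore tentative: compound 4 is expected to be a somewhat weaker inhibitor, with a 5.6-fold higher number from compound 1 to compound 4 (0.74 log units; beyond the scatter), giving an estimated value of 150 nM, within a range of 40 nM to 600 nM.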

Compound 4, half-maximal inhibitory concentration: 220 nM
Beside the measured number, compound 4's estimate is 1.5-fold (0.17 log units) below it; the measured number falls inside the stated range.
By their numbers in this assay, from the lowest: compounds 3 and 1 (each within the scatter of the next); then compound 2; then compound 4.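

Hydroxy on the aromatic carbon ortho to a methylsulfonyl group gives clearly weaker inhibition than pentyl, with an 8.1-fold higher number from compound 1 to compound 4 (0.91 log units; beyond the scatter) for that swap. The same holds against (tert-butyl)sulfanyl, with a 10-fold higher number from compound 3 to compound 4 (1.00 log units; beyond the scatter) for that swap. So this position does not treat all replacements alike: pentyl and (tert-butyl)sulfanyl gave values within the scatter of each other, while hydroxy stands well apart from both, and no evidence is available here to explain the loss.

The compounds shown leave open whether a methoxy group, an amine or a shorter alkyl chain such as ethyl at this position would fall closer to hydroxy or to pentyl. Hydroxy changes both the number of heavy atoms and the number of hydrogen-bond donors at once, and these compounds cannot tell those two changes apart.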